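Swapping fluoro for trifluoromethyl on a diarylamine

The compounds below may be only part of what the source reports. "The series", "measured", "known", "first", "only" and "open" are said of these compounds alone.

Measured so far:
compound 1 `Cc1cc(C)c(Nc2cc(F)cc(Cl)c2)c(C)c1`: 2900 nM
compound 2 `Cc1cc(C)c(Nc2ccc(C)c(Cl)c2)c(C)c1`: 1800 nM

Among the compounds with values here, in an assay on isolated protein for binding affinity to Rap guanine nucleotide exchange factor 4 (Homo sapiens), read by cAMP accumulation (a lower number here means a stronger inhibitor, a higher number a weaker inhibitor), compound 1 gives 2900 nM, the highest of the two numbers measured so far. Its nearest neighbour is compound 2, which in this assay gives 1800 nM; the gap between the two lies within the scatter, so the data do not separate them.

Compound 3 `Cc1cc(C)c(Nc2cc(Cl)cc(C(F)(F)F)c2)c(C)c1` differs from compound 1 at one place: trifluoromethyl in place of fluoro on an aromatic carbon. Within the data shown here, no pair of measured compounds shows this change, so there is no measured step to lean on. The writer expects the step from compound 1 to compound 3 to stay small, at most a modest move toward a lower number, with a 1.5-fold lower number from compound 1 to compound 3 (0.16 log units; within the scatter) as the estimated shift. For compound 3 in this assay the estimate is 2000 nM, expected to fall between 600 nM and 7000 nM.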

Compound 3, half-maximal inhibitory concentration: 500 nM
For compound 3 the middle estimate is 4.0-fold (0.60 log units) above the measured one; the whole stated range lies above it.
By their numbers in this assay, from the lowest: compound 3; then compounds 2 and 1 (each within the scatter of the next).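

In this assay, within the data shown here, trifluoromethyl in place of fluoro on this aromatic carbon brings a 5.8-fold lower number from compound 1 to compound 3 (0.76 log units; beyond the scatter), so this position responds to a change of group, which the earlier compounds, within the scatter of each other, could not show. Here the larger group, with four heavy atoms against one, goes with a lower number rather than a loss, though this rests on a single pair of compounds. No measurement at hand gives a reason for the size of this step.

As far as these compounds go, it remains open whether a nitrile, a methoxy group or a carboxylic acid on the same aromatic carbon would move the number in the same direction. From the compounds shown here alone, it is also open whether the step would hold if the chloro group were replaced by another group.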